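Methyl Gives Way to Ethoxy on the Shared Core

The source may report more compounds than this note shows. Statements on the series, on what has been measured and on what is new or still open speak of the compounds shown alone.

Measured so far:
- compound 1 `CCCCOc1nc(N)c2[nH]c(=O)n(Cc3ccccc3)c2n1` gives 0.001 uM in a functional assay (spleen, spleen) for activation, with Mus musculus as the target; on this read-out higher numbers stand for an effect only at larger amounts of compound and lower numbers for an effect already at smaller amounts
- compound 2 `Nc1ncnc2c1nc(Cl)n2Cc1ccccc1` reaches only a limit of the assay, > 10 uM, in this assay
- compound 3 `Cc1nc(N)c2nc(O)n(Cc3ccccc3)c2n1` gives 1 uM in this assay

Compound 3 stands at the highest of the two numbers available. Its nearest neighbour is compound 1, whose number is lower by a margin far beyond the usual scatter of repeated measurements. For compound 2 nothing more than the limit is known, (the limit of > 10 uM in this assay, at which 1 of the 3 values shown sits).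

Compound 4 `CCOc1nc(N)c2nc(O)n(Cc3ccccc3)c2n1` differs from compound 3 in a single place: ethoxy in place of methyl on an aromatic carbon. Within the data shown here, no pair of measured compounds differs in exactly this way, so the size of this step cannot be read from the data and can only be expected. What the data do show is that, in this assay, the compound that differs from compound 3 in more than one place and carries a longer alkoxy chain on its core, compound 1, gives 0.001 uM.

In this assay compound 4 is therefore expected to sit at a lower number than compound 3, by a step of a 33-fold lower number from compound 3 to compound 4 (1.52 log units; beyond the scatter) that should lie beyond the scatter. The estimated value for compound 4 is 0.03 uM, within a range from 0.003 uM to 0.3 uM.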

Compound 4, minimum effective concentration: 0.1 uM
For compound 4 the middle estimate is 3.3-fold (0.52 log units) below the measured one; the measured number falls inside the stated range.
By their numbers in this assay, from the lowest: compound 1; then compound 4; then compound 3. At a limit, above all of these: compound 2.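

With the step of a 10-fold lower number from compound 3 to compound 4 (1.00 log units; beyond the scatter) in this assay, the shared core gives its first reading of a single change, and that step lies beyond the usual scatter. Among these compounds, it shows that the number responds to what sits on this aromatic carbon between two ring nitrogen atoms, something the earlier compounds could not show, as they differ from one another in more than one place. Ethoxy brings both an oxygen, with its hydrogen-bond acceptor, and a longer reach than methyl, and no data shown separate these two parts of the change or say why the number moves.

The compounds shown leave open whether the number keeps falling as the chain on this carbon grows from ethoxy to propoxy or butoxy on an otherwise unchanged core, or whether it turns back at some length. They also leave open how much depends on the oxygen itself, which propyl, with carbon in place of that oxygen, or an ethylamino group, with nitrogen in its place, would help to tell.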